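The compounds below may be only part of what the source reports. "The series", "measured", "known", "first", "only" and "open" are said of these compounds alone.

Compound 2 `COc1ccc(OCC(=O)N2CCC3(CC2)CN(Cc2ccc(-n4nccn4)cc2)C3)cc1` gives 102 nM in an assay on HEK293 cells for displacement of a labelled ligand from growth hormone secretagogue receptor type 1 (Homo sapiens), with a stated time of 8 h; on this read-out higher numbers stand for weaker inhibition and lower numbers for stronger inhibition. Compound 1 `COc1ccc(OCC(=O)N2CCC3(CC2)CN(Cc2ccc(OCC(C)C)cc2Cl)C3)cc1` gives 86 nM in this assay, a number that lies within the usual scatter of that of compound 2, so the two cannot be told apart. Compound 3 `COc1ccc(OCC(=O)N2CCC3(CC2)CN(Cc2ccc(-n4nccn4)cc2Cl)C3)cc1` differs from compound 2 by chloro in place of hydrogen on an aromatic carbon. For the measured compounds named here, no measured pair shows this change on its own, so there is no direct step to lean on. Because compound 1, which also bears a chloro group on its benzyl ring though with a different second substituent, gives 86 nM, compound 3 is expected to show only a small step of a 1.4-fold lower number from compound 2 to compound 3 (0.13 log units; within the scatter) toward stronger inhibition, if any beyond the scatter. Compound 3 is estimated at 75 nM, between 30 nM and 190 nM.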

Compound 3, half-maximal inhibitory concentration: 14 nM
Compound 3: middle estimate off by 5.4-fold (0.73 log units), on the high side; the whole stated range lies above it.
By their numbers in this assay, from the lowest: compound 3; then compounds 1 and 2 (each within the scatter of the next).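

In this assay, adding chloro on the aromatic carbon ortho to a large group gives a 7.3-fold lower number from compound 2 to compound 3 (0.86 log units; beyond the scatter) when the 2H-1,2,3-triazol-2-yl group is present, a clear move toward stronger inhibition. With chloro kept in place, the second substituent also counts: replacing isobutoxy with 2H-1,2,3-triazol-2-yl gives a 6.1-fold lower number from compound 1 to compound 3 (0.79 log units; beyond the scatter) on this read-out. No measurement here explains either step. On these data alone, whether fluoro or methyl at this carbon would act like chloro remains open, as does how much chloro adds when isobutoxy is the second substituent.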